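The source may hold more compounds than are shown below. What is called first, only, known or untested is meant among the compounds shown, and "the series" means these compounds.

Working notes on the series. In a functional assay on A549 cells (Homo sapiens) for cytotoxicity, read by MTT assay (a lower number here means a stronger inhibitor, a higher number a weaker inhibitor), compound 3 `CCOC(=O)c1oc2cc(O)cc(O)c2c1C` gives 68600 nM, the lower of the two numbers in hand, and compound 2 `Cc1c(C=O)oc2c(C(N)=O)c(O)cc(O)c12` gives 108000 nM, which lies within the scatter of that number, so no order between the two can be read. Compound 1 `CCOC(=O)c1oc2cc(OC)cc(OC)c2c1C`, with both hydroxy groups replaced by methoxy, was reported in this assay as "not active" (no number reported), with no number given. Compound 2 and compound 3 differ in more than one place, so their values show only that an aldehyde with a carbamoyl on the core and an ethyl ester without one land in the same region.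

Compound 4 `CCOC(=O)c1oc2c(C(N)=O)c(O)cc(O)c2c1C` follows from compound 3 by a single change: carbamoyl in place of hydrogen on an aromatic carbon. Going by the values given here, no measured pair in the set isolates this change. Compound 2, which carries the same carbamoyl on the core, gives 108000 nM, within the scatter of compound 3, so the step is expected to be small or none beyond the scatter. Compound 4 is therefore estimated at 75000 nM in this assay, with a range of 25000 nM to 220000 nM; the expected step is a 1.1-fold higher number from compound 3 to compound 4 (0.04 log units; within the scatter).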

Compound 4, half-maximal inhibitory concentration: 24000 nM
Estimate against measurement, compound 4: 3.1-fold (0.49 log units) above; the measured number lies below the stated range.
By their numbers in this assay, from the lowest: compound 4; then compounds 3 and 2 (each within the scatter of the next).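

In this assay, going by these compounds alone, carbamoyl in place of hydrogen on an aromatic carbon gives a 2.9-fold lower number from compound 3 to compound 4 (0.46 log units; beyond the scatter) and thereby provides the first measured pair that isolates this change, with a step beyond the scatter. With the carbamoyl held in place, ethoxy in place of hydrogen on a carbonyl carbon gives a 4.5-fold lower number from compound 2 to compound 4 (0.65 log units; beyond the scatter) and this step also lies beyond the scatter, so compound 4, which carries both the carbamoyl and the ethyl ester, has the lowest number of the measured compounds. Nothing in hand bears on the reason for either step.

From the compounds shown here alone, whether a carboxylic acid or an amine at this aromatic carbon would give a similar step remains open, as does the effect of a longer chain in place of the ethoxy. Also open, going by these compounds, is whether the carbamoyl step holds with methoxy in place of both hydroxy groups, as in compound 1.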